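Dimethylamino on the enamide chain of compound 1

The source may hold more compounds than are shown below. What is called first, only, known or untested is meant among the compounds shown, and "the series" means these compounds.

Compound 1 `CC/C=C/C(=O)Nc1cc2c(N3CCCc4ccccc43)ncnc2cc1OC` gives 6310 nM in a functional assay on PC-3 cells (Homo sapiens) for antiproliferative activity, read by MTT assay, with a stated time of 72 h; a higher number here means a weaker inhibitor, a lower number a stronger inhibitor.
Compound 2 `CC/C=C/C(=O)Nc1cc2c(N3CCCc4ccccc43)ncnc2cc1O[C@@H]1CCOC1` gives 14300 nM in this assay.

Compound 1 holds the lowest of the two numbers shown; its nearest neighbour is compound 2, reached by a 2.3-fold higher number from compound 1 to compound 2 (0.36 log units; beyond the scatter), a modest change that comes from the oxygen substituent on the aromatic ring. Compound 3 `COc1cc2ncnc(N3CCCc4ccccc43)c2cc1NC(=O)/C=C/CN(C)C` differs from compound 1 elsewhere: dimethylamino in place of methyl on a saturated chain carbon bound to a double-bonded chain carbon. For the measured compounds named here, no measured step touches this chain carbon, so the only step in hand, from compound 1 to compound 2, speaks to a different part of the shared core and gives no direct guide. On that basis no shift beyond the scatter is expected for compound 3 in this assay, with wide uncertainty. Compound 3 is therefore estimated at 5000 nM, between 1500 nM and 20000 nM, which would mean an expected step of a 1.3-fold lower number from compound 1 to compound 3 (0.10 log units; within the scatter).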

Compound 3, half-maximal inhibitory concentration: 1750 nM
Compound 3: the middle estimate sits 2.9-fold (0.46 log units) above what was measured; low and high end bracket the measured number.
By their numbers in this assay, from the lowest: compound 3; then compound 1; then compound 2.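

In this assay, the saturated chain carbon bound to a double-bonded chain carbon proves responsive: dimethylamino in place of methyl gives a 3.6-fold lower number from compound 1 to compound 3 (0.56 log units; beyond the scatter). For the compounds shown here, the only earlier step lay at the oxygen on the aromatic ring, where oxolan-3-yl in place of methyl gave a 2.3-fold higher number from compound 1 to compound 2 (0.36 log units; beyond the scatter), so these two changes, at two different places, move the number in opposite directions. Nothing at hand explains the shift seen on the chain.

With dimethylamino as the only amine shown on this chain, it remains open whether a ring amine such as piperidin-1-yl or morpholin-4-yl, a primary amine or a carboxylic acid would give a similar number. Going by these compounds, it is also open how dimethylamino on the chain would behave with oxolan-3-yl on the oxygen.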